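The source may hold more compounds than are shown below. What is called first, only, known or untested is meant among the compounds shown, and "the series" means these compounds.

Measured in an ADME assay on MDCKII-LE cells (Canis lupus familiaris) for permeability; on this read-out higher numbers stand for higher permeability and lower numbers for lower permeability:
- compound 1 `Cc1ccc(Oc2cc(C(=O)Nc3cnc(C)cn3)cc3oc(C)cc23)cc1` (0.3 10^-6 cm/s)
- compound 2 `Cc1cnc(NC(=O)c2cc(Oc3ccc(S(C)(=O)=O)cc3)c3cc(C)oc3c2)cn1` (7.6 10^-6 cm/s)
- compound 3 `CCN(C)C(=O)c1cnc(Oc2cc(C(=O)Nc3cnc(C)cn3)cc3oc(C)cc23)cn1` (24.1 10^-6 cm/s)

Compound 3 holds the highest of the three numbers, and its gaps to compound 2 and compound 1 both lie beyond the scatter.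

Next in the series is compound 4 `CNC(=O)c1cnc(Oc2cc(C(=O)Nc3cnc(C)cn3)cc3oc(C)cc23)cn1`, with hydrogen in place of ethyl on an amide-type nitrogen.

Among the measured compounds shown here, only one measured step is available, a 25-fold higher number from compound 1 to compound 2 (1.40 log units; beyond the scatter). It is large, but it is methylsulfonyl in place of methyl on an aromatic carbon, a different change elsewhere in the molecule. For the measured compounds named here, it therefore gives no direct size for this change, and no measured pair covers the amide-type nitrogen. The expectation is weak and rests on the standing of compound 3 (24.1 10^-6 cm/s) at the top of the set, which leaves a lower number more likely than a higher one.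

The expected change is moderate, a 2.4-fold lower number from compound 3 to compound 4 (0.38 log units; beyond the scatter).

The estimate for compound 4 is 10 10^-6 cm/s, with an expected range of 4 10^-6 cm/s to 22 10^-6 cm/s.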

Compound 4, apparent permeability: 20.9 10^-6 cm/s
The estimate for compound 4 lay 2.1-fold (0.32 log units) below the measured number; low and high end bracket the measured number.
By their numbers in this assay, from the lowest: compound 1; then compound 2; then compounds 4 and 3 (each within the scatter of the next).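

In this assay, hydrogen in place of ethyl on the amide-type nitrogen gives no readable change (a 1.2-fold lower number from compound 3 to compound 4 (0.06 log units; within the scatter)), so ethyl(methyl)carbamoyl and methylcarbamoyl cannot be told apart on this read-out. With the smaller amide, the 5-(methylcarbamoyl)pyrazin-2-yl group on the oxygen still reads above 4-(methylsulfonyl)phenyl (a 2.8-fold higher number from compound 2 to compound 4 (0.44 log units; beyond the scatter)) and far above 4-methylphenyl (a 70-fold higher number from compound 1 to compound 4 (1.84 log units; beyond the scatter)). Nothing measured here accounts for any of these steps.

Open, from the compounds shown here alone, is whether this flat result extends to other amide groups, such as the primary carboxamide, a longer chain such as propyl on the nitrogen, or a morpholine amide. Also open, going by these compounds, is whether a carboxylic acid in place of the amide stays in the same range, as the present reading rests on a single pair at this nitrogen.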